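A few compounds are considered here, and "the series" means these few. Any claim that something is new, unique, unknown or untested is made for them only; others in the source may bear on it.

Of the compounds shown here, three built on a shared core have been tested in a functional assay on SK-BR-3 cells (Homo sapiens) for cytotoxicity, read by sulforhodamine B assay, with a stated time of 3 days; a lower number here means that less compound is needed, a higher number that more compound is needed for the effect. Compound 1 `COCc1c(C)coc1-c1ccc2c(c1OC)CCCC2(C)C` gives 18.5 uM. Compound 2 `CCOc1c(-c2occ(C)c2CO)ccc2c1CCCC2(C)C` gives 9.9 uM, and compound 3 `Cc1coc(-c2ccc3c(c2O)CCCC3)c1C(=O)O` gives 32.4 uM. The number for compound 1 lies between those of compound 2 and compound 3, and its gap to each of them is within the usual scatter of repeated measurements. Compound 4 `COc1c(-c2occ(C)c2C(=O)O)ccc2c1CCCC2(C)C` has not yet been measured; it differs from compound 1 in one place: carboxy in place of methoxymethyl on an aromatic carbon. Among the compounds with values here, no single-change step between measured compounds is available to anchor this exchange, and the three measured numbers give no hint of a step beyond the scatter. The value of compound 4 is expected to be 24 uM, between 8 uM and 70 uM. This corresponds to an expected step of a 1.3-fold higher number from compound 1 to compound 4 (0.11 log units; within the scatter), which would stay within the scatter.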

Compound 4, concentration for half-maximal effect: 25.5 uM
Compound 4: middle estimate off by 1.1-fold (0.03 log units), on the low side, within the range that was stated.
By their numbers in this assay, from the lowest: compounds 2, 1, 4 and 3 (each within the scatter of the next, the first and the last beyond it).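

In this assay putting carboxy in place of methoxymethyl on this aromatic carbon gives a 1.4-fold higher number from compound 1 to compound 4 (0.14 log units; within the scatter) and so does not tell the two groups apart. Within the data shown here, this is the first comparison here of compounds that differ in one place, and the hydrogen-bond donor that carboxy adds leaves the step within the scatter at this position. No measurement at hand explains this result.

On these data alone, whether an amine or a longer chain at this position would also stay within the scatter remains open. One pair also cannot show whether the same exchange would give a similar step on another core.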